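This account rests on a few compounds, and the source may have more. Where it says the series, first, only, none or still open, it means among the compounds named here.

The measured compounds so far:
compound 1, `Cc1c(NC(=O)COc2ccc(/C=C3\SC(=O)NC3=O)cc2)c(=O)n(-c2ccccc2)n1C`, gives < 100000 nM
compound 2, `Cc1cnc(NC(=O)COc2ccc(/C=C3\SC(=O)NC3=O)cc2)s1`, gives < 100000 nM
compound 3, `CCCCC1=NC2(CCCC2)C(=O)N1C(=O)COc1ccc(/C=C2/SC(=O)NC2=O)cc1`, gives < 100000 nM

All three were tested in a functional assay on MCF7 cells (Homo sapiens) for cytotoxicity, read by sulforhodamine B assay, with a stated time of 48 h; a lower number here means a stronger inhibitor of growth, a higher number a weaker inhibitor of growth. For compound 2 the result is only a limit of the assay, not a number. The same is true of compound 1, whose value is a limit. Compound 3 likewise shows only a limit. So compound 2 cannot be placed above or below either of the other two: the three share (the limit of < 100000 nM in this assay, at which 3 of the 3 values shown sit), and nothing separates them.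

The next compound to be measured is compound 4, `O=C(COc1ccc(/C=C2\SC(=O)NC2=O)cc1)Nc1nc2ccccc2s1`. It differs from compound 2 in a single place: 1,3-benzothiazol-2-yl in place of 5-methyl-1,3-thiazol-2-yl on an amide-type nitrogen. For the measured compounds named here, no step between measured compounds exists to lean on, so the size of this change in this assay is open. Since every measured compound sits at the limit, compound 4 is expected to land in the same region, with no step beyond the scatter: the expected step is a step that the limit leaves unreadable from compound 2 to compound 4. Compound 4 is therefore estimated at 40000 nM, within a range from 8000 nM to 100000 nM, with a real chance that again only a limit is reported.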

Compound 4, concentration for total growth inhibition: < 100000 nM
Compound 4 gave a limit, no number (the forecaster's own chance of this, stated with the estimate: 60%); the middle value lies beyond the limit too.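

Compound 4, like compound 2, returned only a limit, so no step can be read for 1,3-benzothiazol-2-yl in place of 5-methyl-1,3-thiazol-2-yl on an amide-type nitrogen. All the compounds shown stand together at one limit: the limit of < 100000 nM in this assay, at which 4 of the 4 values shown sit. They leave open how strongly each one inhibits growth, and whether this exchange changes that at all.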